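A few compounds are considered here, and "the series" means these few. Any claim that something is new, unique, unknown or untested is made for them only; others in the source may bear on it.

Measured so far:

compound 1, `c1ccc(COc2ccccc2Nc2ncnc3cc4c(cc23)OCCOCCOCCO4)cc1` — in a functional assay on HepG2 cells (Homo sapiens) for antiproliferative activity, read by MTT assay, with a stated time of 72 h (a higher number here means a weaker inhibitor, a lower number a stronger inhibitor), compound 1 gives 37300 nM
compound 2, `O=[N+]([O-])c1ccc(COc2ccccc2Nc2ncnc3cc4c(cc23)OCCOCCOCCO4)cc1` — in this assay compound 2 gives 60800 nM
compound 3, `c1ccc(COc2cccc(Nc3ncnc4cc5c(cc34)OCCOCCOCCO5)c2)cc1` — for compound 3 this assay reports only a limit, > 100000 nM

Compound 1 and compound 2 share the same core and differ in one place: nitro in place of hydrogen on an aromatic carbon. That change produced a 1.6-fold higher number from compound 1 to compound 2 (0.21 log units; within the scatter), so the two values cannot be told apart. Compound 3 has the same atoms as compound 1 joined differently; the difference between the two cores is not broken down here. Its result sits at the limit of > 100000 nM in this assay, at which 1 of the 3 values shown sits, so only a limit is known for it.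

Compound 4, `O=[N+]([O-])c1ccc(COc2cccc(Nc3ncnc4cc5c(cc34)OCCOCCOCCO5)c2)cc1`, is not yet measured. It stands to compound 3 as compound 2 stands to compound 1: nitro in place of hydrogen on an aromatic carbon. The place of the change is described in the same words for both pairs, so this is the same change, seen here twice in all.

The expectation for compound 4 rests on a 1.6-fold higher number from compound 1 to compound 2 (0.21 log units; within the scatter), a step within the scatter, and on the limit of compound 3. Nitro in place of hydrogen is therefore expected to leave compound 4 near compound 3, and the step that the limit leaves unreadable from compound 3 to compound 4 is an estimate, not a measurement. In this assay compound 4 is expected to give about 150000 nM, within a range from 60000 nM to 400000 nM. Since compound 3 itself is reported only as a limit, compound 4 is most likely to be reported as a limit too.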

Compound 4, half-maximal inhibitory concentration: > 100000 nM
Compound 4: only a limit was reported; the forecaster's own chance of this, stated with the estimate: 80%; the middle value lies beyond the limit too.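

In this assay compound 4 gives > 100000 nM, which is a limit and not a number. Compound 3 is also reported only as a limit, so no step from compound 3 to compound 4 can be read: the limit of > 100000 nM in this assay, at which 2 of the 4 values shown sit.

The compounds shown leave open whether nitro in place of hydrogen on an aromatic carbon changes the result at all on the core of compound 3.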